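Sulfamoyl Added to the Phenyl Ring of Compound 3

A few compounds are considered here, and "the series" means these few. Any claim that something is new, unique, unknown or untested is made for them only; others in the source may bear on it.

Measured compounds:
compound 1, `O=C(O)Cc1sc(COc2ccc(Cl)cc2)nc1-c1ccc(Cl)cc1`, 370 nM
compound 2, `CCC(c1ccccc1)c1nc(-c2ccc(Cl)cc2)c(CC(=O)O)s1`, > 100000 nM
compound 3, `O=C(O)Cc1sc(C(c2ccc(F)cc2)c2ccc(F)cc2)nc1-c1ccccc1`, 240 nM

Of the compounds shown here, three sharing one core have been tested in an in vitro functional assay on HEK285-7 cells for antagonist activity at prostaglandin D2 receptor 2 (Homo sapiens), read by BRET and beta-arrestin recruitment; on this read-out lower numbers stand for stronger inhibition and higher numbers for weaker inhibition. Compound 1 gives 370 nM. Compound 3 gives 240 nM, a number that sits with that of compound 1 within the usual scatter, so the two cannot be told apart on these data. Compound 2 is the exception: its result is only a limit, > 100000 nM, and no number is known for it, as noted in the limit of > 100000 nM in this assay, at which 1 of the 3 values shown sits.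

The next compound to be measured is compound 4, `NS(=O)(=O)c1cccc(-c2nc(C(c3ccc(F)cc3)c3ccc(F)cc3)sc2CC(=O)O)c1`. It differs from compound 3 in one place: sulfamoyl in place of hydrogen on an aromatic carbon. Among the measured compounds shown here, the change is small and leaves the rest of the molecule untouched, and no pair among the measured compounds shows what such an addition does in this assay. The step from compound 3 to compound 4 is therefore expected to stay close to the scatter, with the estimate leaning slightly toward a lower number, as a 1.3-fold lower number from compound 3 to compound 4 (0.12 log units; within the scatter). Compound 4 is estimated at 180 nM, with a range from 40 nM to 900 nM.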

Compound 4, half-maximal inhibitory concentration: 710 nM
Beside the measured number, compound 4's estimate is 3.9-fold (0.60 log units) below it; the range from low to high includes it.
By their numbers in this assay, from the lowest: compounds 3, 1 and 4 (each within the scatter of the next, the first and the last beyond it). At a limit, above all of these: compound 2.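

Among the compounds shown here, until now no two measured compounds differing in one place showed how this assay responds to a change on the phenyl group of the shared core, and phenyl to 3-sulfamoylphenyl now supplies that first reading: a 3.0-fold higher number from compound 3 to compound 4 (0.47 log units; beyond the scatter). The step is modest, and with the sulfamoyl group on this aromatic carbon, meta to a large group, compound 4 still gives a measured number, 710 nM, and not a limit. No measurement shown bears on the reason for this rise.

Going by these compounds, a single pair cannot separate the effect of the sulfamoyl group itself from the effect of its place on the ring, and it remains open whether a methylsulfonyl group, a carboxylic acid or an amine at this same position would give a number closer to that of compound 3, 240 nM, or whether sulfamoyl on a different carbon of this ring would do so. Also open, on these data alone, is whether the same addition would produce a step of similar size on a different compound, as one pair establishes no general pattern.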